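Hydroxy Gives Way to 4-Chlorophenyl in a Cell Assay

This account rests on a few compounds, and the source may have more. Where it says the series, first, only, none or still open, it means among the compounds named here.

In a functional assay on CCRF-CEM cells (Homo sapiens) (a lower number here means a stronger inhibitor, a higher number a weaker inhibitor), compound 2 (`OC[C@H]1C[C@@H](Cn2cnc3c(O)ncnc32)c2ccccc21`) gives 24 ug/mL. For the measured compounds named here, this is the highest of the three numbers measured so far, which makes it the weakest inhibitor of the set, beyond the scatter of both others. Compound 1 (`Cn1ncc2c1[C@@H](CO[Si](c1ccccc1)(c1ccccc1)C(C)(C)C)C[C@H]2Cn1cnc2c(O)ncnc21`) gives 3.2 ug/mL and compound 3 (`Cn1ncc2c1[C@H](Cn1cnc3c(Cl)ncnc31)C[C@@H]2CO[Si](c1ccccc1)(c1ccccc1)C(C)(C)C`) gives 3.2 ug/mL, but neither differs from compound 2 in only one place.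

Compound 4 (`OC[C@H]1C[C@@H](Cn2cnc3c(-c4ccc(Cl)cc4)ncnc32)c2ccccc21`) keeps the rest of compound 2 and changes a single site, with 4-chlorophenyl in place of hydroxy on an aromatic carbon. Going by the values given here, no measured pair shows this change, so any forecast for this assay is loose. A moderate step toward a stronger inhibitor is expected, a 2.7-fold lower number from compound 2 to compound 4 (0.43 log units; beyond the scatter). Among the compounds with values here, the only guide to how far it might go is the lower number of compound 1 at 3.2 ug/mL, and a step of no consequence cannot be ruled out. The estimated value for compound 4 is 9 ug/mL, with an expected range from 3 ug/mL to 30 ug/mL.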

Compound 4, half-maximal inhibitory concentration: 0.63 ug/mL
Compound 4: the middle estimate sits 14-fold (1.15 log units) above what was measured, and the stated range ends above it.
By their numbers in this assay, from the lowest: compound 4; then compounds 1 and 3 (each within the scatter of the next); then compound 2.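

For the compounds shown here, the first single-site comparison in this assay shows that this aromatic carbon, on the six-membered aromatic ring with 2 nitrogen, accepts much more than a hydroxy: 4-chlorophenyl in place of hydroxy gives a 38-fold lower number from compound 2 to compound 4 (1.58 log units; beyond the scatter), the only step read so far. The entering group brings 7 heavy atoms and carries 0 hydrogen-bond donors and 0 hydrogen-bond acceptors, so the donor and acceptor of the hydroxy are not required here for a lower number. Nothing measured accounts for the size of this step.

Going by these compounds, it remains open whether the chlorine matters or the phenyl ring alone carries the step, a question that an unsubstituted phenyl at this carbon would settle. On these data alone, it is equally open whether an amine there would behave like the hydroxy or like the 4-chlorophenyl.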